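This account rests on a few compounds, and the source may have more. Where it says the series, first, only, none or still open, it means among the compounds named here.

Of the compounds shown here, three have been tested so far in a functional assay on KYSE-450 cells (Homo sapiens) for inhibition, read by MTT assay, with a stated time of 48 h; a lower number here means a stronger inhibitor, a higher number a weaker inhibitor. Compound 1 `COc1cc(NCc2ccccc2)cc(OC)c1OC` returns > 80000 nM as a limit of the assay, not as a number. Compound 3 `C/C=C/C(=O)N(Cc1cc(OC)c(OC)c(OC)c1)c1ccc(OC)c(O)c1` gives 9160 nM as a measured number. Compound 2 `COc1ccc(CN(C(C)=O)c2cc(OC)c(OC)c(OC)c2)cc1O` gives 160 nM as the lowest of the two numbers in hand, and the gap between these two lies beyond the scatter.

Compound 4 `COc1ccc(CN(C(=O)CO)c2cc(OC)c(OC)c(OC)c2)cc1O` has not yet been measured. The change from compound 2 is hydroxy in place of hydrogen on a saturated chain carbon bound to a carbonyl carbon and in words it is hydroxy in place of hydrogen on a saturated chain carbon bound to a carbonyl carbon, so that acetyl becomes (hydroxymethyl)carbonyl. Among the compounds with values here, no measured pair shows this change, so the size of the step in this assay has to be judged without a direct precedent. A modest loss is expected, with compound 4 a somewhat weaker inhibitor by a step probably just beyond the scatter. Starting from compound 2 at 160 nM as the lowest number seen, the expectation leans upward rather than downward. The estimated move a 2.5-fold higher number from compound 2 to compound 4 (0.40 log units; beyond the scatter) is therefore a rise of moderate size. For compound 4 the estimated value is 400 nM with an expected range from 90 nM to 2500 nM once it is measured.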

Compound 4, half-maximal inhibitory concentration: 370 nM
Beside the measured number, compound 4's estimate is 1.1-fold (0.03 log units) above it; measured number inside the range.
By their numbers in this assay, from the lowest: compound 2; then compound 4; then compound 3. At a limit, above all of these: compound 1.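

In this assay, the acetyl group of compound 2 tolerates the change to (hydroxymethyl)carbonyl, since hydroxy in place of hydrogen on a saturated chain carbon bound to a carbonyl carbon brings only a modest loss, a 2.3-fold higher number from compound 2 to compound 4 (0.36 log units; beyond the scatter). Within the data shown here, this is the first pair that differs in one place, so this position now has a measured step: it lies beyond the scatter, yet compound 4 still gives 370 nM, showing that the added hydrogen-bond donor and acceptor do not abolish activity here. Nothing measured for these compounds explains the step, which stands as a size without a cause.

As far as these compounds go, it remains open whether an amine or a methoxy group on the same saturated chain carbon would give a step of similar size, and whether a longer chain, such as propanoyl in place of acetyl, would raise or lower the number. A single pair also cannot show whether this change would cost as much on a different core.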